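The source may hold more compounds than are shown below. What is called first, only, known or untested is meant among the compounds shown, and "the series" means these compounds.

Notes on the series. Compound 1 `CCC(C)(C)Cc1c[nH]c(CCc2ccc(-c3ccncc3)cc2)n1`, compound 2 `CCC(C)(C)Cc1c[nH]c(CCc2ccc(-n3cncn3)cc2)n1` and compound 3 `CCC(C)(C)Cc1c[nH]c(CCc2ccc(-c3cccnc3C(=O)O)cc2)n1` share one core and differ only in the group carried on an aromatic carbon of the terminal six-membered ring of carbon only. In a functional assay on HEK293 cells for agonist activity at Bombesin receptor subtype-3 (Mus musculus), read by luminescence and calcium flux, with a stated time of 10 min (on this read-out higher numbers stand for an effect only at larger amounts of compound and lower numbers for an effect already at smaller amounts), compound 1 gives 15 nM, compound 2 gives 12 nM and compound 3 gives 14 nM. Where compound 3 stands is within the scatter of both others; the steps read a 1.1-fold lower number from compound 1 to compound 3 (0.03 log units; within the scatter) and a 1.2-fold higher number from compound 2 to compound 3 (0.07 log units; within the scatter), and the remaining pair shows the same picture with a 1.3-fold lower number from compound 1 to compound 2 (0.10 log units; within the scatter). None of the three exchanges at this aromatic carbon moved the read-out beyond the scatter.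

Compound 4 `CCC(C)(C)Cc1c[nH]c(CCc2ccc(-c3ccns3)cc2)n1` is not yet measured. The change from compound 3 is 1,2-thiazol-5-yl in place of 2-carboxypyridin-3-yl on an aromatic carbon. All three measured steps bear on it, since each of them also exchanges the group at this same aromatic carbon, and each stayed within the scatter. The expectation for compound 4 in this assay is therefore no step beyond the scatter, and no change at the digits printed from compound 3 to compound 4 (within the scatter) is what is expected. Compound 4 is estimated at 14 nM, with a range from 6 nM to 35 nM. The measured compounds hold no five-membered ring with sulfur, so the range is kept wide.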

Compound 4, half-maximal effective concentration: 3.1 nM
Beside the measured number, compound 4's estimate is 4.5-fold (0.65 log units) above it; the whole stated range lies above it.
By their numbers in this assay, from the lowest: compound 4; then compounds 2, 3 and 1 (each within the scatter of the next).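

At this aromatic carbon, para to a large group, the read-out in this assay does respond to the group carried: the steps read a 4.5-fold lower number from compound 3 to compound 4 (0.65 log units; beyond the scatter) and a 3.9-fold lower number from compound 2 to compound 4 (0.59 log units; beyond the scatter) and a 4.8-fold lower number from compound 1 to compound 4 (0.68 log units; beyond the scatter) and so set compound 4 apart from all three others, whereas the earlier exchanges all stayed within the scatter. For the compounds shown here, a five-membered aromatic ring alone does not mark the difference, since the 1H-1,2,4-triazol-1-yl of compound 2 stays within the scatter of the six-membered aromatic groups of compound 1 and compound 3, while the 1,2-thiazol-5-yl of compound 4 is the only group of the four that holds sulfur. Nothing available explains why this group stands apart from the others.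

From the compounds shown here alone, whether the step belongs to the sulfur or to the arrangement of the ring atoms stays open, and a thiophen-2-yl, a 1,3-thiazol-5-yl or a 1,2-oxazol-5-yl group at this carbon would separate these readings. Also open, going by these compounds, is whether 1,2-thiazol-5-yl gives a similar step when a shorter chain replaces the branched alkyl chain on the shared core.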